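A few compounds are considered here, and "the series" means these few. Any claim that something is new, unique, unknown or untested is made for them only; others in the source may bear on it.

Measured compounds in a toxicity assay on cells (Macrophage, Mus musculus, strain BALB/c) for cytotoxicity, read by MTT assay; a lower number here means a stronger inhibitor, a higher number a weaker inhibitor:
- compound 1, `COc1cc(O)cc(O)c1C(=O)/C=C/c1ccc(Cl)cc1`, gives 19000 nM.
- compound 3, `C=CCOc1cc(OC)c(C(=O)/C=C/c2ccc([N+](=O)[O-])cc2)c(OCC=C)c1`, gives 13200 nM.
- compound 2, `COCc1cc(COC)c(C(=O)/C=C/c2ccc(OC)cc2)c(OC)c1`, gives only a limit, > 250000 nM.

Of the three values, one sits at the limit (the limit of > 250000 nM in this assay, at which 1 of the 3 values shown sits). Among the two numbers, compound 1 and compound 3 lie within the usual scatter of each other, so no order between them is claimed.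

The next compound is compound 4, `COc1cc(O)cc(O)c1C(=O)/C=C/c1ccc(C)cc1`. It differs from compound 1 in one place: methyl in place of chloro on an aromatic carbon. Within the data shown here, no measured pair shows this kind of change, so there is no step to lean on; the expectation is a step no larger than the scatter, in either direction. Compound 4 is therefore estimated at 20000 nM, with a range from 8000 nM to 50000 nM, meaning an expected step of a 1.1-fold higher number from compound 1 to compound 4 (0.02 log units; within the scatter) in this assay.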

Compound 4, half-maximal inhibitory concentration: 16500 nM
Compound 4: the middle estimate sits 1.2-fold (0.08 log units) above what was measured; low and high end bracket the measured number.
By their numbers in this assay, from the lowest: compounds 3, 4 and 1 (each within the scatter of the next). At a limit, above all of these: compound 2.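

In this assay, among these compounds, the change from 4-chlorophenyl to 4-methylphenyl gives the first single-place pair, with a 1.2-fold lower number from compound 1 to compound 4 (0.06 log units; within the scatter), so chloro and methyl cannot be told apart at this position, para to a large group. No measured property bears on this result.

On these data alone, whether an amine, a carboxylic acid or a longer chain at this position would move the number stays open. So does whether the same change reads alike on the cores of compound 2 and compound 3.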